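This account rests on a few compounds, and the source may have more. Where it says the series, first, only, none or still open, it means among the compounds named here.

Measured in a functional assay on the whole organism for inhibition, with Homo sapiens as the target, read by hemolysis; on this read-out lower numbers stand for stronger inhibition and higher numbers for weaker inhibition:
- compound 1 `CC1=CCC([C@]2(C)Cc3c(O)ccc(C(=O)O)c3O2)CC1`: 2400000 nM
- compound 2 `CC1=CCC([C@]2(C)Cc3c(O)cc(C=O)cc3O2)CC1`: 515000 nM
- compound 3 `COc1cc(C=O)cc2c1C[C@@](C)(C1CC=C(C)CC1)O2`: > 1040000 nM (a limit of the assay, not a number)

Compound 1 gives 2400000 nM in this assay and compound 2 gives 515000 nM. Going by the values given here, compound 3 stands only at a limit of the assay, > 1040000 nM, as the one such value among the three (the limit of > 1040000 nM in this assay, at which 1 of the 3 values shown sits). Among the compounds with values here, the single step that touches it, an at least 2.0-fold higher number from compound 2 to compound 3 (0.30 log units; that floor lies within the scatter), therefore has no firm upper end. Compound 4 `CC1=CCC([C@]2(C)Cc3c(Oc4ccccc4)cc(C=O)cc3O2)CC1` differs from compound 3 by phenyl in place of methyl on an oxygen on an aromatic ring. Within the data shown here, no measured step bears on this change directly; the only neighbouring step went toward weaker inhibition and sits at the floor of the scatter. Compound 4 is expected at 1000000 nM, between 300000 nM and 3000000 nM, meaning an estimated step of an at least 1.0-fold lower number from compound 3 to compound 4 (0.01 log units; that floor lies within the scatter).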

Compound 4, half-maximal inhibitory concentration: > 862000 nM
Compound 4: no number, only a limit; the forecaster's own chance of this, stated with the estimate: 50%; the middle value is on the limit's open side.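

With phenyl on the oxygen on an aromatic ring, compound 4 stands in this assay only at a limit of the assay, > 862000 nM, so a second group at this place has given a limit and not a number: the limit of > 862000 nM in this assay, at which 1 of the 4 values shown sits. The step from methoxy to phenoxy, which joins two limits, cannot be read. Phenyl in place of hydrogen gives an at least 1.6-fold higher number from compound 2 to compound 4 (0.22 log units; that floor lies within the scatter), with no firm upper end, so phenyl, like methyl, brings no sign of stronger inhibition at this place.

From the compounds shown here alone, the true size of that step remains open. So does whether an amine or a longer chain on this oxygen would give a number within the range of the assay.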